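The compounds below may be only part of what the source reports. "The series", "measured", "known", "first", "only" and "open" are said of these compounds alone.

Three compounds have been measured in an ADME assay on NCM460 cells (Homo sapiens) for cytotoxicity, read by MTT assay, with a stated time of 72 h; on this read-out higher numbers stand for weaker inhibition and lower numbers for stronger inhibition:

Compound 1 `O=C(NCC1CCCCC1)c1cccc(/C=C2\CC(=O)N(c3ccccc3)C2=O)c1`: compound 1 gives > 100000 nM, which is a limit of the assay rather than a number.
Compound 2 `Cc1ccc(NC(=O)c2cccc(/C=C3\CC(=O)N(c4ccccc4)C3=O)c2)cc1C`: compound 2 gives > 100000 nM, also a limit.
Compound 3 `O=C(Nc1ccccc1)c1cccc(/C=C2\CC(=O)N(c3ccccc3)C2=O)c1`: compound 3 gives > 100000 nM, again a limit.

Compound 3 therefore stands at the same limit as the other two, and nothing in the numbers places any of the three above or below another. The steps between them, a step that the two limits leave unreadable from compound 1 to compound 2, a step that the two limits leave unreadable from compound 1 to compound 3 and a step that the two limits leave unreadable from compound 2 to compound 3, cannot be read in size, as both ends of each step sit at a limit; the limit of > 100000 nM in this assay, at which 3 of the 3 values shown sit, sums this up.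

Compound 4 `Cc1ccc(NC(=O)c2cccc(/C=C3\CC(=O)N(c4ccccc4)C3=O)c2)cc1` differs from compound 3 by a single change: methyl in place of hydrogen on an aromatic carbon. Going by the values given here, no measured step shows the effect of methyl in place of hydrogen on an aromatic carbon; the three steps above concern a different part of the molecule and are unreadable in any case. With all three measured values sitting at the limit (the limit of > 100000 nM in this assay, at which 3 of the 3 values shown sit), the expectation for compound 4 is no step beyond the scatter, a step that the limit leaves unreadable from compound 3 to compound 4. Compound 4 is estimated at 150000 nM, between 60000 nM and 400000 nM, and is expected most likely to be reported only as a limit once more.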

Compound 4, half-maximal inhibitory concentration: > 100000 nM
Compound 4 was reported as a limit; the forecaster's own chance of this, stated with the estimate: 85%; the middle value lies beyond the limit too.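

In this assay compound 4 gives > 100000 nM, which is a limit of the assay and not a number. Going by these compounds alone, its steps to compound 1, compound 2 and compound 3 cannot be read in size, so no new step emerges: the limit of > 100000 nM in this assay, at which 4 of the 4 values shown sit. The compounds shown leave open whether changing the group on the amide nitrogen makes any difference in this assay.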